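Swapping a sulfur-linked benzoxazole for a methylpiperazine

This account rests on a few compounds, and the source may have more. Where it says the series, first, only, none or still open, it means among the compounds named here.

Of the compounds shown here, three sharing one core have been measured in a functional assay on MCF7 cells (Homo sapiens) for cytotoxicity, read by MTT assay, with a stated time of 24 h, tested at 32 ug/mL; a higher number here means a stronger effect of the compound at the concentration tested, a lower number a weaker effect. Compound 1 `Cn1c(-c2ccc(NC(=O)CSc3nc4cc(Cl)ccc4o3)cc2)nc(-c2ccccc2)c1-c1ccccc1` gives 59.7%. Compound 2 `Cc1ccc2oc(SCC(=O)Nc3ccc(-c4nc(-c5ccccc5)c(-c5ccccc5)n4C)cc3)nc2c1` gives 57.7%, which is the lowest of the three numbers, though the gap to compound 1, a number 2 percentage points lower from compound 1 to compound 2 (within the scatter), lies within the scatter. Compound 3 `Cn1cnnc1SCC(=O)Nc1ccc(-c2nc(-c3ccccc3)c(-c3ccccc3)n2C)cc1` gives 89.2%, and the step of a number 31.5 percentage points higher from compound 2 to compound 3 (beyond the scatter) is beyond the scatter, as is a number 29.5 percentage points higher from compound 1 to compound 3 (beyond the scatter).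

Compound 4 `CN1CCN(CC(=O)Nc2ccc(-c3nc(-c4ccccc4)c(-c4ccccc4)n3C)cc2)CC1` has not yet been measured. It differs from compound 2 in one place: 4-methylpiperazin-1-yl in place of (5-methyl-1,3-benzoxazol-2-yl)sulfanyl on a saturated chain carbon bound to a carbonyl carbon. Among the compounds with values here, no measured step removes the sulfur or brings in a saturated ring, so the bearing of the earlier steps is indirect. Still, the two steps that replaced the benzoxazole with a smaller heteroaryl, a number 31.5 percentage points higher from compound 2 to compound 3 (beyond the scatter) and a number 29.5 percentage points higher from compound 1 to compound 3 (beyond the scatter), both raised the read-out, which supports expecting a gain once the benzoxazole is gone again. Compound 4 is therefore expected to reach 70%, within a range of 45% to 92%, an estimated step of a number 12.3 percentage points higher from compound 2 to compound 4 (beyond the scatter).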

Compound 4, a percentage reported as activity, at one concentration (the size of the read-out at that concentration, not a potency): 46.2%
Compound 4: middle estimate off by 23.8 percentage points, on the high side; low and high end bracket the measured number.
By their numbers in this assay, from the lowest: compound 4; then compounds 2 and 1 (each within the scatter of the next); then compound 3.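

Taking the benzoxazole away does not by itself raise the read-out in this assay: with 4-methylpiperazin-1-yl on the saturated chain carbon bound to a carbonyl carbon, the number falls (a number 11.5 percentage points lower from compound 2 to compound 4 (beyond the scatter); a number 13.5 percentage points lower from compound 1 to compound 4 (beyond the scatter)). Set against the triazole, the same group gives a much larger drop (a number 43 percentage points lower from compound 3 to compound 4 (beyond the scatter)), so among these four compounds the high read-out goes with (4-methyl-4H-1,2,4-triazol-3-yl)sulfanyl, not with the mere absence of the benzoxazole. No measurement shown here accounts for this difference.

As far as these compounds go, what remains open is whether the drop goes with losing the sulfur or with bringing in the saturated ring. A dimethylamino group on the same carbon, or a triazole joined there without the sulfur, would help separate the two.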